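Side-chain variation on the shared core: compound 3

The source may report more compounds than this note shows. Statements on the series, on what has been measured and on what is new or still open speak of the compounds shown alone.

Compound 2 `Cc1nnc(SCC(=O)Nc2ccc(-c3nc(-c4ccccc4)c(-c4ccccc4)n3C)cc2)s1` stands highest of the two numbers in a functional assay on MCF7 cells (Homo sapiens) for cytotoxicity, read by MTT assay, with a stated time of 24 h, tested at 0.64 ug/mL (a higher number here means a stronger effect of the compound at the concentration tested, a lower number a weaker effect), where compound 2 gives 35.1%, while compound 1 `Cn1c(-c2ccc(NC(=O)CCl)cc2)nc(-c2ccccc2)c1-c1ccccc1` gives 3.4%. For the measured compounds named here, the only measured step, a number 31.7 percentage points higher from compound 1 to compound 2 (beyond the scatter), touches the same place as the change to compound 3 `CCN1CCN(CC(=O)Nc2ccc(-c3nc(-c4ccccc4)c(-c4ccccc4)n3C)cc2)CC1`, namely (4-ethylpiperazin-1-yl in place of (5-methyl-1,3,4-thiadiazol-2-yl)sulfanyl on a saturated chain carbon bound to a carbonyl carbon). That step was large but exchanged a different group, so it shows only that this place moves the read-out. Going by the values given here, no measured step bears directly on the present change, and the expected step of a number 15.1 percentage points lower from compound 2 to compound 3 (beyond the scatter) is therefore uncertain and set below compound 2. Compound 3 is estimated at 20%, within 3% to 45%.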

Compound 3, a percentage reported as activity, at one concentration (the size of the read-out at that concentration, not a potency): 4.7%
Beside the measured number, compound 3's estimate is 15.3 percentage points above it; measured number inside the range.
By their numbers in this assay, from the lowest: compounds 1 and 3 (each within the scatter of the next); then compound 2.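

In this assay, 4-ethylpiperazin-1-yl in place of (5-methyl-1,3,4-thiadiazol-2-yl)sulfanyl gives a number 30.4 percentage points lower from compound 2 to compound 3 (beyond the scatter), so the gain at this place does not follow from replacing chloro with just any ring-bearing group. The same group in place of chloro gives a number 1.3 percentage points higher from compound 1 to compound 3 (within the scatter). Of these three side chains, only (5-methyl-1,3,4-thiadiazol-2-yl)sulfanyl stands apart, and nothing available accounts for this difference.

Going by these compounds, it remains open whether the higher number goes with the sulfur link or with the ring, and a methylsulfanyl or phenylsulfanyl group on the same chain carbon would separate the two.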